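Pentafluorophenyl Ether in Place of a Fluorophenyl Ether

The source may report more compounds than this note shows. Statements on the series, on what has been measured and on what is new or still open speak of the compounds shown alone.

Compound 2 `CC(C)[C@H](NC(=O)COc1cccc2ccccc12)C(=O)N[C@@H](CC(=O)O)C(=O)COc1ccccc1F` gives 15700 nM in a functional assay with Homo sapiens as the target; on this read-out lower numbers stand for stronger inhibition and higher numbers for weaker inhibition. Compound 1 `CC(C)[C@H](NC(=O)COc1cccc2ccccc12)C(=O)N[C@@H](CC(=O)O)C(=O)COc1ccc(Oc2ccc(C(F)(F)F)cc2)cc1` gives 24900 nM in this assay, and the gap between these two values lies within the usual scatter, so compound 2 cannot be set apart from compound 1 on the numbers shown. Compound 3 `CC(C)[C@H](NC(=O)COc1cccc2ccccc12)C(=O)N[C@@H](CC(=O)O)C(=O)COc1c(F)c(F)c(F)c(F)c1F` is not yet measured; it differs from compound 2 by 2,3,4,5,6-pentafluorophenyl in place of 2-fluorophenyl on an oxygen on a saturated carbon. For the measured compounds named here, no measured pair shows a step of this kind, so the step of a 1.2-fold lower number from compound 2 to compound 3 (0.08 log units; within the scatter) is expected to stay within the scatter, in either direction. Compound 3 is estimated at 13000 nM in this assay, with a range from 4000 nM to 40000 nM.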

Compound 3, half-maximal inhibitory concentration: 8890 nM
Estimate against measurement, compound 3: 1.5-fold (0.17 log units) above; the range from low to high includes it.
By their numbers in this assay, from the lowest: compounds 3, 2 and 1 (each within the scatter of the next, the first and the last beyond it).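

In this assay, for the compounds shown here, 2,3,4,5,6-pentafluorophenyl in place of 2-fluorophenyl on an oxygen on a saturated carbon gives a 1.8-fold lower number from compound 2 to compound 3 (0.25 log units; within the scatter) and is the only step at this position that can be read here. This position therefore accepts the fully fluorinated ring without a change that can be told from the scatter. No available evidence bears on this result.

From the compounds shown here alone, it remains open how a plain phenyl, or a phenyl carrying an amine or a carboxylic acid, would read at this position.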